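A few compounds are considered here, and "the series" means these few. Any claim that something is new, unique, unknown or untested is made for them only; others in the source may bear on it.

Measured compounds:

Compound 1, `O=C(CCc1cccc2c1B(O)OC2)NCc1ccccc1`. In a functional assay on MDA-MB-231 cells (Homo sapiens) for antiproliferative activity, read by MTT assay, with a stated time of 72 h (on this read-out higher numbers stand for weaker inhibition and lower numbers for stronger inhibition), compound 1 gives > 100000 nM, which is a limit of the assay and not a number.

Compound 2, `C#Cc1ccccc1NC(=O)CCc1cccc2c1B(O)OC2`. In this assay compound 2 gives 1300 nM.

Compound 3, `O=C(CCc1cccc2c1B(O)OC2)Nc1cccc(-c2cccc(F)c2)c1`. In this assay compound 3 gives 570 nM.

Among the two compounds with a numerical value, compound 3 holds the lowest number, and the gap from compound 2 to compound 3 lies beyond the usual scatter of repeated measurements. Compound 1 differs from both in that it sits at a limit, (the limit of > 100000 nM in this assay, at which 1 of the 3 values shown sits), so only its boundary is known.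

The next compound, compound 4, `O=C(CCc1cccc2c1B(O)OC2)Nc1cccc(-c2cccc(C(F)(F)F)c2)c1`, keeps the whole of compound 3 apart from one change: trifluoromethyl in place of fluoro on an aromatic carbon. With only three compounds shown and no measured pair that differs in one place, nothing here shows how such a change shifts the number; the expectation below rests only on the neighbouring value of compound 3.

For compound 4 the expected value in this assay is 500 nM, within a range from 150 nM to 1600 nM. This estimate means a step of a 1.1-fold lower number from compound 3 to compound 4 (0.06 log units; within the scatter) that is expected to stay within the scatter, with no clear direction.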

Compound 4, half-maximal inhibitory concentration: 410 nM
Compound 4: the middle estimate sits 1.2-fold (0.09 log units) above what was measured; low and high end bracket the measured number.
By their numbers in this assay, from the lowest: compounds 4 and 3 (each within the scatter of the next); then compound 2. At a limit, above all of these: compound 1.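

This is the first pair shown that differs in one place, and in this assay the change gives a 1.4-fold lower number from compound 3 to compound 4 (0.14 log units; within the scatter). On this aromatic carbon, then, fluoro with its 1 heavy atom can give way to trifluoromethyl with its 4 heavy atoms, with no shift in the number that can be told apart from the usual scatter of the measurement. Nothing measured here bears on why the two compounds read alike, so these data offer no explanation for it.

For the compounds shown here, whether an amine, a carboxylic acid or a methoxy group on this same aromatic carbon would also leave the number in place remains open; fluoro and trifluoromethyl are the only two groups compared here, and they say little about how the position would respond to a very different group. Also open, as far as these compounds go, is what plain hydrogen on this carbon would give, and whether a longer chain joining the amide carbonyl to the shared core would move the number in either direction.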